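The source may report more compounds than this note shows. Statements on the series, on what has been measured and on what is new or still open speak of the compounds shown alone.

Among the measured compounds shown here, compound 3 `Cc1cc(CN(CC2CCCCC2)C(CC(=O)O)c2ccc(Cl)cc2)ccc1OCCN1C(=O)CCC1=O` stands second highest of the three numbers measured so far in an assay on CHO cells for displacement of a labelled ligand from C-X-C chemokine receptor type 3 (Homo sapiens), with a stated time of 60 min (on this read-out higher numbers stand for weaker inhibition and lower numbers for stronger inhibition), where compound 3 gives 81 nM. Its nearest neighbour is compound 2 `CCCCN(Cc1ccc(OCCN2C(=O)CCC2=O)c(C)c1)C(CC(=O)O)c1ccc(Cl)cc1`, which in this assay gives 61 nM; the difference a 1.3-fold higher number from compound 2 to compound 3 (0.12 log units; within the scatter) lies within the scatter. Furthest from it is compound 1 `CCN(Cc1ccc(OCCN2C(=O)CCC2=O)c(C)c1)C(CC(=O)O)c1ccc(Cl)cc1`, which in this assay gives 424 nM. The step of a 5.2-fold lower number from compound 1 to compound 3 (0.72 log units; beyond the scatter) and the step of a 7.0-fold lower number from compound 1 to compound 2 (0.84 log units; beyond the scatter) both show that enlarging the group on the amine nitrogen beyond ethyl brings the number down.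

Compound 4 `Cc1cc(CN(CCC(F)(F)F)C(CC(=O)O)c2ccc(Cl)cc2)ccc1OCCN1C(=O)CCC1=O` is compound 3 with 2,2,2-trifluoroethyl in place of cyclohexyl on a saturated chain carbon bound to an amine nitrogen. For the measured compounds named here, this change runs opposite to the two steps from compound 1: the group that enters is the smaller one and has no ring, and it is shorter than the propyl of compound 2 as well, though it carries fluorine, which none of the measured steps tests. The account therefore expects a modest rise in the number for compound 4, smaller than the steps from compound 1 and possibly within the scatter, so that a 1.6-fold higher number from compound 3 to compound 4 (0.21 log units; within the scatter) is the estimated step. Compound 4 is estimated at 130 nM, with a range from 45 nM to 400 nM.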

Compound 4, half-maximal inhibitory concentration in the C-X-C chemokine receptor type 3 assay: 650 nM
Estimate against measurement, compound 4: 5.0-fold (0.70 log units) below; measured number above the stated range.
By their numbers in the C-X-C chemokine receptor type 3 assay, from the lowest: compounds 2 and 3 (each within the scatter of the next); then compounds 1 and 4 (each within the scatter of the next).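

Among the compounds shown here, at this position, a larger group on the amine nitrogen does not by itself bring the number down: in the C-X-C chemokine receptor type 3 assay compound 4 gives 650 nM, the exchange of cyclohexyl for 2,2,2-trifluoroethyl gives an 8.0-fold higher number from compound 3 to compound 4 (0.90 log units; beyond the scatter) and the exchange of ethyl for trifluoromethyl at the chain end gives an 11-fold higher number from compound 2 to compound 4 (1.03 log units; beyond the scatter), so the butyl of compound 2 and the cyclohexylmethyl of compound 3 have no counterpart in the 3,3,3-trifluoropropyl of compound 4. Adding trifluoromethyl in place of hydrogen at the end of the ethyl of compound 1 gives a 1.5-fold higher number from compound 1 to compound 4 (0.19 log units; within the scatter), so this chain end, unlike the ethyl that leads to compound 2, leaves the number where compound 1 had it. In a physicochemical assay for solubility, at pH 1.1 (a higher number here means a more soluble compound, a lower number a less soluble compound), compound 3 gives 3000000 nM and compound 4 gives 3000000 nM; the same exchange shows no change at the digits printed from compound 3 to compound 4 (within the scatter) and so does not separate the two compounds.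

Nothing at hand explains why trifluoromethyl and ethyl part so widely at this chain end. As far as these compounds go, whether a plain propyl, a difluoromethyl end, a longer fluorinated chain or a cyclohexyl ring carrying fluorine would stand with compound 2 or with compound 4 stays open.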